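The compounds below may be only part of what the source reports. "The series", "measured", "known", "first", "only" and "open" are said of these compounds alone.

Measured compounds:
compound 1 `Brc1ccc(-c2ncc(OCC3CCNCC3)nc2-c2ccc(Br)cc2)cc1`: 72.5%
compound 2 `N#Cc1ccc(-c2ncc(OCC3CCNCC3)nc2-c2ccc(C#N)cc2)cc1`: 0%

Both compounds share the same core and differ only in the groups on the two outer aromatic rings. In an assay on isolated protein for inhibition of histone acetyltransferase p300 (Homo sapiens), read by scintillation counting, with stated times of 10 min and 30 min, tested at 10 uM (a lower number here means less inhibition, a higher number more inhibition at the concentration tested (going by the name of the read-out)), compound 1 gives 72.5%, while compound 2 gives 0%. Within the data shown here, compound 2 therefore stands at the lowest of the two numbers; its only neighbour, compound 1, lies higher by a margin beyond the usual scatter. Among the measured compounds shown here, no step between measured compounds that differ in one place is available, so the pair shows only that the dicyano compound loses the inhibition seen for the dibromo compound.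

Compound 3 `N#Cc1ccc(-c2nc(OCC3CCNCC3)cnc2-c2ccc(Br)cc2)cc1` is not yet measured. Against compound 2 the change is bromo in place of cyano on an aromatic carbon. Structurally compound 3 sits between the two measured compounds, one ring carrying bromo as in compound 1, the other cyano as in compound 2. The step is expected to be an increase in this assay, beyond the scatter, of about a number 35 percentage points higher from compound 2 to compound 3 (beyond the scatter). Compound 3 is accordingly estimated at 35% in this assay, with a range from 5% to 65%.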

Compound 3, a percentage reported as inhibition, at one concentration (the size of the read-out at that concentration, not a potency): 21%
Compound 3: middle estimate off by 14 percentage points, on the high side; the measured number falls inside the stated range.
By their numbers in this assay, from the lowest: compound 2; then compound 3; then compound 1.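

In this assay the change 4-cyanophenyl to 4-bromophenyl on one ring gives a number 21 percentage points higher from compound 2 to compound 3 (beyond the scatter) as a modest step, while the reverse exchange, cyano in place of bromo, gives a number 51.5 percentage points lower from compound 1 to compound 3 (beyond the scatter) as a large one. A single exchange at this position therefore moves the number beyond the scatter from either side, and one bromo alongside one cyano does not reach the level of the dibromo compound 1. No measurement on hand accounts for the difference between bromo and cyano here.

It remains open whether the two outer rings contribute equally, since only one mixed compound is shown. Also open, from the compounds shown here alone, is how other groups at this position, such as chloro, methyl, methoxy or a carboxylic acid, would read.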